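The compounds below may be only part of what the source reports. "The series", "measured", "known", "first", "only" and "open" are said of these compounds alone.

Working notes on the series.

Three compounds have numbers in an assay on isolated protein for inhibition of steroid 5-alpha-reductase (Rattus norvegicus); a higher number here means a weaker inhibitor, a lower number a stronger inhibitor. Compound 1 `COc1ccccc1N1CCN(CCCCOc2ccc(C(=O)Nc3ccccc3OCCCC(=O)O)cc2)CC1` gives 43000 nM. Compound 2 `CCc1ccc(C(CCN2CCN(c3ccccc3OC)CC2)Oc2ccc(NC(=O)c3ccccc3OCCCC(=O)O)cc2)cc1` gives 130 nM. Compound 3 `COc1ccccc1N1CCN(CCC(Oc2ccc(C(=O)Nc3ccccc3OCCCC(=O)O)cc2)c2ccccc2)CC1` gives 1000 nM. Among these three numbers compound 3 stands second highest: compound 2 shows the lower number of the pair, compound 1 the higher, and both gaps lie beyond the usual scatter, so compound 3 is neither the strongest nor the weakest inhibitor of the three.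

Compound 4 `COc1ccccc1N1CCN(CCC(Oc2ccc(C(=O)Nc3ccccc3OCCCC(=O)O)cc2)c2ccc(Br)cc2)CC1` differs from compound 3 in one place: bromo in place of hydrogen on an aromatic carbon, para to a large group. Among the measured compounds shown here, no step between two measured compounds isolates such a change, so the size of the step is not anchored by the numbers above. Compound 2 carries a substituted phenyl at the corresponding position and gives a lower number than compound 3, but compound 2 differs from compound 3 elsewhere as well, so nothing is claimed from it.

The expectation for compound 4 is a step from compound 3 of a 2.0-fold lower number from compound 3 to compound 4 (0.30 log units; within the scatter), in the direction of a lower number, of a size near the edge of the scatter. The estimate for compound 4 in this assay is 500 nM, with a range from 150 nM to 1500 nM.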

Compound 4, half-maximal inhibitory concentration: 210 nM
Compound 4: middle estimate off by 2.4-fold (0.38 log units), on the high side, within the range that was stated.
By their numbers in this assay, from the lowest: compounds 2 and 4 (each within the scatter of the next); then compound 3; then compound 1.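

In this assay, among the compounds shown here, bromo in place of hydrogen on an aromatic carbon, para to a large group, gives a 4.8-fold lower number from compound 3 to compound 4 (0.68 log units; beyond the scatter) and is the only step that isolates one change. The earlier compounds shown here could not show this, as no two of them differed in one place only; the phenyl to 4-bromophenyl change now shows that this position responds to substitution, and here in the direction of a stronger inhibitor. No measurement at hand gives a reason for the step.

From the compounds shown here alone, whether the step is specific to bromo remains open: chloro or methoxy at the same place would test this. Also open, going by these compounds, is whether the step holds when the butanoic acid chain of compound 3 and compound 4 is replaced by a shorter carboxylic acid chain.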